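The source may report more compounds than this note shows. Statements on the series, on what has been measured and on what is new or still open speak of the compounds shown alone.

Measured in an ADME assay on MT4 cells (Homo sapiens) for cytotoxicity, with a stated time of 5 days; on this read-out lower numbers stand for higher toxicity in this test and higher numbers for lower toxicity in this test:
Compound 1 `O=C(CCl)Nc1ccc(Cl)cc1NS(=O)(=O)c1c(F)cccc1F`: 175000 nM
Compound 2 `O=c1[nH]c2ccc(Cl)cc2n1S(=O)(=O)c1cccc(F)c1`: 128000 nM

Only these two compounds have been measured, and their values lie within the usual scatter of each other, so compound 1 stands level with compound 2 and no order can be drawn between them. The step followed here leads from compound 1 to compound 3 `N#Cc1cccc(S(=O)(=O)Nc2cc(Cl)ccc2NC(=O)CCl)c1`, which has not yet been measured. The change is 3-cyanophenyl in place of 2,6-difluorophenyl on a sulfonyl sulfur. The rest of the structure stays as it is in compound 1.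

Within the data shown here, no measured pair differs in one place only, so no step shows directly what such a swap does. The expectation rests on the two values alone, which offer no sign of a large change. In this assay, a slight move towards a lower number is expected, but none beyond the scatter. The estimated change is a 1.5-fold lower number from compound 1 to compound 3 (0.16 log units; within the scatter). For compound 3 the estimated value is 120000 nM, with an expected range from 40000 nM to 300000 nM.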

Compound 3, half-maximal cytotoxic concentration: > 155000 nM
Compound 3: no number, only a limit; the forecaster's own chance of this, stated with the estimate: 25%; middle value at least 1.2-fold (0.11 log units) from the limit.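

In this assay compound 3 gives > 155000 nM, which is a limit of the assay and not a number. The step from compound 1 to compound 3 therefore cannot be read: the limit of > 155000 nM in this assay, at which 1 of the 3 values shown sits.

The compounds shown leave open whether 3-cyanophenyl in place of 2,6-difluorophenyl on a sulfonyl sulfur changes the result in this assay at all, and in which direction.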